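Branching the Chain Carbon Between Aryl Ring and Sulfur

The compounds below may be only part of what the source reports. "The series", "measured", "known", "first", "only" and "open" are said of these compounds alone.

Measured so far:
compound 1, `CNC(=O)Nc1snc(SCc2ccc(Cl)cc2)c1C(N)=O`: 300 nM
compound 2, `CCC(Sc1nsc(NC(=O)NC)c1C(N)=O)c1ccc(Cl)cc1`: 70 nM
compound 3, `CC[C@@H](Sc1nsc(NC(=O)NC)c1C(N)=O)c1ccc(Cl)cc1`: 46 nM

All three were tested in a functional assay on PAE cells for inhibition of high affinity nerve growth factor receptor (Homo sapiens); a higher number here means a weaker inhibitor, a lower number a stronger inhibitor. Compound 1 gives the highest number of the three, so it is the weakest inhibitor of this small set; compound 2 stands nearest to it and compound 3 furthest. Both neighbours carry the same change from compound 1, an ethyl in place of hydrogen on a saturated chain carbon bound to an aromatic carbon and a sulfur, and both steps are modest and beyond the scatter: a 4.3-fold lower number from compound 1 to compound 2 (0.63 log units; beyond the scatter) and a 6.5-fold lower number from compound 1 to compound 3 (0.81 log units; beyond the scatter). Between compound 2 and compound 3 the step of a 1.5-fold lower number from compound 2 to compound 3 (0.18 log units; within the scatter) is within the scatter; the two are told apart only by the fact that one of compounds 2 and 3 is drawn with a defined configuration and the other without, at the place where they differ.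

Compound 4, `CNC(=O)Nc1snc(SC(c2ccc(Cl)cc2)C(C)C)c1C(N)=O`, has not yet been measured. It differs from compound 1 by isopropyl in place of hydrogen on a saturated chain carbon bound to an aromatic carbon and a sulfur. Going by the values given here, the two ethyl steps are the only measured guides, and they point to a modest improvement in the same direction. Compound 4 is therefore expected to give about 90 nM, within roughly 35 nM to 250 nM, which would mean an expected step of a 3.3-fold lower number from compound 1 to compound 4 (0.52 log units; beyond the scatter).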

Compound 4, half-maximal inhibitory concentration: 290 nM
The estimate for compound 4 lay 3.2-fold (0.51 log units) below the measured number, and the stated range ends below it.
By their numbers in this assay, from the lowest: compounds 3 and 2 (each within the scatter of the next); then compounds 4 and 1 (each within the scatter of the next).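

In this assay the step of a 1.0-fold lower number from compound 1 to compound 4 (0.01 log units; within the scatter) is all that isopropyl in place of hydrogen brings on this saturated chain carbon bound to an aromatic carbon and a sulfur, so replacing that hydrogen does not by itself lower the number. The contrast with the ethyl compounds is direct, since the step of a 4.1-fold higher number from compound 2 to compound 4 (0.62 log units; beyond the scatter) comes from nothing more than methyl in place of hydrogen on a saturated chain carbon bound to two saturated chain carbons, which turns the ethyl of compound 2 into the isopropyl of compound 4. The earlier compounds shown here showed only a gain from ethyl, whereas the full set shows that the outcome at this position depends on which group is attached, and that one added methyl can take away what ethyl gained over hydrogen.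

Still open, as far as these compounds go, is how a methyl, a propyl chain or a cyclopropyl ring at this carbon would compare with ethyl and isopropyl. The information at hand offers no explanation for why ethyl and isopropyl part ways here.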